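This account rests on a few compounds, and the source may have more. Where it says the series, first, only, none or still open, it means among the compounds named here.

In an assay on isolated protein for inhibition of Tryptophan 2,3-dioxygenase (Homo sapiens), read by fluorescence and mass spectrometry, with stated times of 5 min and 15 min (on this read-out higher numbers stand for weaker inhibition and lower numbers for stronger inhibition), compound 1 `Nc1oncc1-c1ccccc1` gives 140 nM, while compound 2 `Nc1oncc1-c1cccc(Cl)c1` gives 500 nM. Among the measured compounds shown here, compound 2 therefore has the higher of the two numbers so far in this assay, its only neighbour being compound 1; the step of a 3.6-fold higher number from compound 1 to compound 2 (0.55 log units; beyond the scatter) is the single measured change in the set.

Compound 3 `COc1cccc(-c2cnoc2N)c1` is not yet measured. It differs from compound 2 by methoxy in place of chloro on an aromatic carbon. For the measured compounds named here, no measured pair exchanges one substituent for another at this carbon; the one step that bears on the site is the step from compound 1 to compound 2, which put a chloro where a hydrogen had been and raised the number beyond the scatter. That step says a substituent on this carbon is tolerated but costs something; it cannot say whether a methoxy costs more or less than the chloro it replaces.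

Compound 3 is therefore expected to land near compound 2, with the uncertainty spanning both directions, as the step of a 1.3-fold lower number from compound 2 to compound 3 (0.10 log units; within the scatter) expresses. In this assay compound 3 is estimated at 400 nM, within a range from 150 nM to 1100 nM.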

Compound 3, half-maximal inhibitory concentration: 3100 nM
For compound 3 the middle estimate is 7.8-fold (0.89 log units) below the measured one; the whole stated range lies below it.
By their numbers in this assay, from the lowest: compound 1; then compound 2; then compound 3.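

In this assay the exchange of chloro for methoxy on this aromatic carbon gives a 6.2-fold higher number from compound 2 to compound 3 (0.79 log units; beyond the scatter) and so shows that the two substituents are not interchangeable here, which the earlier step from hydrogen to chloro could not reveal. Measured from hydrogen, methoxy gives a 22-fold higher number from compound 1 to compound 3 (1.35 log units; beyond the scatter) where chloro gave a 3.6-fold higher number from compound 1 to compound 2 (0.55 log units; beyond the scatter) and the cost at this carbon therefore depends on which group stands there, not merely on the presence of a substituent. Nothing given here explains why methoxy carries the higher number of the two in this assay.

The compounds shown leave open how other groups on this carbon would compare with chloro and methoxy, for instance an amine, a hydroxyl, a fluorine atom or a longer chain such as ethoxy. They also leave open whether the same order of hydrogen, chloro and methoxy would hold on any other carbon of the six-membered ring, since every step here concerns a single carbon.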